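Replacing the 1,3-benzoxazol-2-yl group of compound 1

The compounds below may be only part of what the source reports. "The series", "measured", "known", "first", "only" and "open" are said of these compounds alone.

Going by the values given here, in a functional assay on Bel-7402 cells (Homo sapiens) for cytotoxicity, read by MTT assay, with a stated time of 48 h (on this read-out higher numbers stand for weaker inhibition and lower numbers for stronger inhibition), compound 1 `CCn1cc(-c2nc3ccccc3o2)c(=O)c2cc(F)c(N3CCNCC3)nc21` gives 16800 nM, the higher of the two numbers measured so far. Among the compounds with values here, its only measured neighbour, compound 2 `CCn1cc(-c2nc3ccc([N+](=O)[O-])cc3o2)c(=O)c2cc(F)c(N3CCNCC3)nc21`, gives 3000 nM. These two differ by nitro in place of hydrogen on an aromatic carbon, and the result is a 5.6-fold lower number from compound 1 to compound 2 (0.75 log units; beyond the scatter), a modest step beyond the scatter.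

Compound 3 `CCn1cc(-c2nc3ccc(N)cc3[nH]2)c(=O)c2cc(F)c(N3CCNCC3)nc21` has not yet been measured, and its change from compound 1 is larger: a group of 10 heavy atoms (7 carbon, 3 nitrogen; one five-membered aromatic ring with 2 hetero atoms, one six-membered aromatic ring of carbon only) in place of a group of 9 heavy atoms (7 carbon, 1 nitrogen, 1 oxygen; one five-membered aromatic ring with 2 hetero atoms, one six-membered aromatic ring of carbon only), on an aromatic carbon. The whole 1,3-benzoxazol-2-yl group leaves, and a group with no common name enters on the same aromatic carbon. Within the data shown here, only one measured step bears on this, and it is an imperfect guide. Among the measured compounds shown here, compound 2 keeps the 1,3-benzoxazol-2-yl group, and no measured compound carries the entering group. Taking a 5.6-fold lower number from compound 1 to compound 2 (0.75 log units; beyond the scatter) as the only hint, a modest move toward a lower number in this assay is expected, though with wide uncertainty. The expected step is a 2.4-fold lower number from compound 1 to compound 3 (0.38 log units; beyond the scatter). For compound 3 the estimated value is 7000 nM, with an expected range of 1800 nM to 25000 nM.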

Compound 3, half-maximal inhibitory concentration: 93300 nM
Beside the measured number, compound 3's estimate is 13-fold (1.12 log units) below it, and the stated range ends below it.
By their numbers in this assay, from the lowest: compound 2; then compound 1; then compound 3.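

The swap of the whole 1,3-benzoxazol-2-yl group in this assay gives a 5.6-fold higher number from compound 1 to compound 3 (0.74 log units; beyond the scatter), the only step shown that moves toward weaker inhibition, whereas the nitro change gives a 5.6-fold lower number from compound 1 to compound 2 (0.75 log units; beyond the scatter). Changes to compound 1 can therefore move the number in either direction, and a group of similar size with the same two aromatic rings does not guarantee a similar result: the entering group has 3 nitrogen atoms and no oxygen, and 2 hydrogen-bond donors where the leaving group has 0. No measurement shown gives a reason for this rise.

This single step bundles several differences, so it cannot tell whether the loss of the ring oxygen or the gain of the extra nitrogen atoms accounts for the higher number. On these data alone, it also remains open how a methoxy group, a chlorine atom or a carboxylic acid would behave in place of the nitro group of compound 2 , and whether any of them would extend the move toward stronger inhibition.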